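The source may report more compounds than this note shows. Statements on the series, on what has been measured and on what is new or still open speak of the compounds shown alone.

Three compounds that share one core and differ only in the group on an amide-type nitrogen have been tested in a functional assay on MCF7 cells (Homo sapiens) for antiproliferative activity, read by MTT assay, with a stated time of 48 h; on this read-out higher numbers stand for weaker inhibition and lower numbers for stronger inhibition. Compound 1 `O=C(N[C@@H](CCCCCCSSc1ccccn1)C(=O)NC1CCCCC1)OCc1ccccc1`, carrying cyclohexyl, gives 19600 nM. Compound 2 `O=C(N[C@@H](CCCCCCSSc1ccccn1)C(=O)Nc1nc(-c2ccccc2)cs1)OCc1ccccc1`, carrying 4-phenyl-1,3-thiazol-2-yl, gives 3200 nM. Compound 3 `O=C(N[C@@H](CCCCCCSSc1ccccn1)C(=O)Nc1ccccc1-c1ccccc1)OCc1ccccc1`, carrying 2-phenylphenyl, gives 20800 nM, which places it level with compound 1 and at a clearly weaker number than compound 2.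

Compound 4 `O=C(N[C@@H](CCCCCCSSc1ccccn1)C(=O)Nc1ccc(-c2ccccc2)cc1)OCc1ccccc1` has the same atoms as compound 3, joined differently: 4-phenylphenyl in place of 2-phenylphenyl on an amide-type nitrogen. In words, 4-phenylphenyl stands in place of 2-phenylphenyl on an amide-type nitrogen. For the measured compounds named here, no measured pair isolates such a rearrangement, so the evidence is indirect. The data show a 1.1-fold higher number from compound 1 to compound 3 (0.03 log units; within the scatter), but also a 6.1-fold lower number from compound 1 to compound 2 (0.79 log units; beyond the scatter) and a 6.5-fold higher number from compound 2 to compound 3 (0.81 log units; beyond the scatter). Changes at this nitrogen have therefore produced either no step beyond the scatter or a modest one. Going by the values given here, compound 2 is the only measured compound at a lower number, and its group, like 4-phenylphenyl, has a 4-phenyl substituent on its ring. On that slender basis, a modest step towards stronger inhibition is expected rather than a large one. The expected change is a 2.3-fold lower number from compound 3 to compound 4 (0.36 log units; beyond the scatter). For compound 4 the estimated value is 9000 nM, with an expected range from 2800 nM to 23000 nM.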

Compound 4, half-maximal inhibitory concentration: 18100 nM
The estimate for compound 4 lay 2.0-fold (0.30 log units) below the measured number; the measured number falls inside the stated range.
By their numbers in this assay, from the lowest: compound 2; then compounds 4, 1 and 3 (each within the scatter of the next).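

In this assay, for the compounds shown here, the pair of compound 3 and compound 4 isolates a rearrangement of the same atoms on the amide-type nitrogen for the first time: 4-phenylphenyl in place of 2-phenylphenyl gives a 1.1-fold lower number from compound 3 to compound 4 (0.06 log units; within the scatter), so the place of the second phenyl ring makes no difference that can be read here. Going by these compounds alone, the new group also stands level with cyclohexyl, with a 1.1-fold lower number from compound 1 to compound 4 (0.03 log units; within the scatter), yet a 5.7-fold higher number from compound 2 to compound 4 (0.75 log units; beyond the scatter), which shows that a 4-phenyl substituent alone does not go with the lower number and leaves compound 2, with its 4-phenyl-1,3-thiazol-2-yl, as the only compound set apart from the other three. Nothing measured on these compounds accounts for this separation.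

On these data alone, it remains open whether the lower number of compound 2 would survive with a plain 1,3-thiazol-2-yl lacking the phenyl ring, or with another ring such as a 4-phenylpyridin-2-yl on the same nitrogen. The compounds shown also say nothing about the rest of the shared core, for example a shorter chain or a free thiol in place of the pyridyl disulfide.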